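Adding a bromo to the most active compound

A few compounds are considered here, and "the series" means these few. Any claim that something is new, unique, unknown or untested is made for them only; others in the source may bear on it.

Measured in a functional assay on HCT-116 cells (Homo sapiens) for antiproliferative activity, read by MTT assay, with a stated time of 48 h; on this read-out lower numbers stand for stronger inhibition and higher numbers for weaker inhibition:
- compound 1 `COc1ccc(CN(C(=O)CSc2nc3ccccc3s2)c2cc(OC)c(OC)c(OC)c2)cc1O`: 182 nM
- compound 2 `COc1cc(CN(C(=O)CSc2nc3ccccc3s2)c2cc(OC)c(OC)c(OC)c2)cc(OC)c1OC`: 65300 nM
- compound 3 `COc1ccc(CN(C(=O)CSc2nc3ccccc3s2)c2cc(OC)c(OC)c(OC)c2)cc1F`: 1830 nM

The lowest number of these three belongs to compound 1. The nearest gap is a 10-fold higher number from compound 1 to compound 3 (1.00 log units; beyond the scatter), and the widest is a 360-fold higher number from compound 1 to compound 2 (2.55 log units; beyond the scatter).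

Compound 4 `COc1ccc(CN(C(=O)CSc2nc3cc(Br)ccc3s2)c2cc(OC)c(OC)c(OC)c2)cc1O` is not yet measured. It differs from compound 1 by a single change: bromo in place of hydrogen on an aromatic carbon. Among the compounds with values here, no measured step tests this change, since compound 1, compound 2 and compound 3 all keep hydrogen at that place. The steps seen so far all concern the group on the saturated chain carbon bound to the amide-type nitrogen. They still give a warning, as a 10-fold higher number from compound 1 to compound 3 (1.00 log units; beyond the scatter) shows that swapping one group can shift the number clearly. A small rise is therefore the cautious expectation, though a fall cannot be ruled out, and the range must stay wide. The expected change is a 1.6-fold higher number from compound 1 to compound 4 (0.22 log units; within the scatter). For compound 4 the estimated value is 300 nM, with an expected range from 80 nM to 1200 nM.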

Compound 4, half-maximal inhibitory concentration: 3380 nM
For compound 4 the middle estimate is 11-fold (1.05 log units) below the measured one; measured number above the stated range.
By their numbers in this assay, from the lowest: compound 1; then compounds 3 and 4 (each within the scatter of the next); then compound 2.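

Within the data shown here, the earlier compounds changed only the group on the saturated chain carbon, so compound 4 gives the first reading at a different place: an aromatic carbon of the six-membered carbon-only ring, part of a fused system of two rings. In this assay, bromo in place of hydrogen there gives a 19-fold higher number from compound 1 to compound 4 (1.27 log units; beyond the scatter) and shows that this place in compound 1 is not indifferent to substitution, since a single added heavy atom clearly weakens the antiproliferative effect. The data offer no measured explanation for this loss.

With bromo as the only substituent shown at this carbon, it remains open whether the loss is specific to bromo or follows any replacement of hydrogen. An amine, a carboxylic acid or a methoxy group at the same place could separate these two possibilities.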